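The compounds below may be only part of what the source reports. "The series", "measured", "known", "first", "only" and "open" are said of these compounds alone.

Working notes on the series, all read in a functional assay on A549 cells (Homo sapiens) for cytotoxicity, read by MTT assay, with a stated time of 68 h; on this read-out lower numbers stand for stronger inhibition and higher numbers for weaker inhibition. Compound 1 `COc1ccc(-c2cc(NC(=O)C(Cl)Cl)cc(-c3ccc(OC)cc3)c2)cc1` gives 20800 nM. Compound 2 `COc1ccc(-c2cc(NC(=O)C(Cl)Cl)cc(-c3ccc(OC)c(F)c3)c2)cc1F` gives 1950 nM. Compound 3 `COc1ccc(-c2cccc(NC(=O)C(Cl)Cl)c2)cc1` gives 8530 nM, the second highest of the three numbers, lying below the value of compound 1 and above that of compound 2.

The next entry is compound 4 `COC(=O)c1ccc(-c2cccc(NC(=O)C(Cl)Cl)c2)cc1`, which keeps the rest of compound 3 and carries methoxycarbonyl in place of methoxy on an aromatic carbon, para to a large group (methoxycarbonyl in place of methoxy on an aromatic carbon).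

Among the compounds with values here, only one single-place step has been measured: a 2.4-fold lower number from compound 1 to compound 3 (0.39 log units; beyond the scatter), a modest change with hydrogen in place of 4-methoxyphenyl on an aromatic carbon. It bears on compound 4 only indirectly, since it leaves the methoxy group of compound 3 untouched. Within the data shown here, compound 2 differs from compound 1 in more than one place, so its value supplies no single step. Among the measured compounds shown here, no measured step therefore replaces methoxy, and the data give no direction for this change. A step no larger than the modest one measured is the working assumption, with none beyond the scatter expected.

In this assay the expected step is a 1.1-fold lower number from compound 3 to compound 4 (0.03 log units; within the scatter). The estimate for compound 4 is 8000 nM, with an expected range of 2800 nM to 23000 nM.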

Compound 4, half-maximal inhibitory concentration: > 50000 nM
Compound 4 ended at the assay's limit (the forecaster's own chance of this, stated with the estimate: 5%); at least 6.2-fold (0.79 log units) between middle value and limit.
By their numbers in this assay, from the lowest: compound 2; then compound 3; then compound 1. At a limit, above all of these: compound 4.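

On the aromatic ring that carries methoxy in compound 3, the position para to a large group proves sensitive to the group placed there. In this assay, within the data shown here, methoxycarbonyl in place of methoxy gives an at least 5.8-fold higher number from compound 3 to compound 4 (0.76 log units; beyond the scatter), the first measured single-place step that alters this group rather than removing the second 4-methoxyphenyl. The value of compound 4 is a limit and not a number, so the step gives only a lower bound on the size of the change: the limit of > 50000 nM in this assay, at which 1 of the 4 values shown sits.

The compounds shown leave open whether an amine, a carboxylic acid, a primary amide or a simple methyl at this position would stay close to compound 3 or also reach the limit, and so whether the outcome belongs to methoxycarbonyl alone or extends to other replacements of methoxy. They also leave open whether methoxycarbonyl would have the same outcome on the fluorinated methoxyphenyl groups of compound 2, which has no single-place partner here.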